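The source may report more compounds than this note shows. Statements on the series, on what has been measured and on what is new or still open speak of the compounds shown alone.

The study compares two measured inhibitors and one untested analogue. Compound 1 `CC[C@H](C)C(=O)O[C@H]1C[C@@H](C)C=C2C=C[C@H](C)[C@H](CC[C@@H]3C[C@@H](O)CC(=O)O3)[C@]21C` is a fused bicyclic lactone-bearing compound; in an assay on microsomes from liver for inhibition of 3-hydroxy-3-methylglutaryl-coenzyme A reductase (Rattus norvegicus) (on this read-out lower numbers stand for stronger inhibition and higher numbers for weaker inhibition), compound 1 gives 3 nM. Compound 2 `Cc1ccc(-c2nc(C(F)(F)F)n(CC[C@@H](O)C[C@@H](O)CC(=O)O)c2-c2ccc(F)cc2)cc1` carries an imidazole core with a trifluoromethyl group, a 4-fluorophenyl group, a 6-carboxy-3,5-dihydroxyhexyl chain on the ring nitrogen and a 4-methylphenyl group; in this assay compound 2 gives 43 nM. Of the two measured compounds, compound 2 has the higher number, and the gap to compound 1 lies beyond the usual scatter, so compound 2 is the weaker inhibitor of this pair.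

Compound 3 `Cc1cc(-c2nc(C(F)(F)F)n(CC[C@@H](O)C[C@@H](O)CC(=O)O)c2-c2ccc(F)cc2)cc(C)c1F` differs from compound 2 in one place: 4-fluoro-3,5-dimethylphenyl in place of 4-methylphenyl on an aromatic carbon. The new group sits on an aromatic carbon of the five-membered ring, next to the ring nitrogen and next to the ring atom that bears the 4-fluorophenyl group. For the measured compounds named here, no measured pair in this set shows this change, so the expected step from compound 2 to compound 3 in this assay, a 1.4-fold lower number from compound 2 to compound 3 (0.16 log units; within the scatter), is taken to be small and within the scatter, possibly toward slightly stronger inhibition. The estimated value for compound 3 in this assay is 30 nM, with a range from 8 nM to 120 nM.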

Compound 3, half-maximal inhibitory concentration: 32 nM
Estimate against measurement, compound 3: 1.1-fold (0.03 log units) below; low and high end bracket the measured number.
By their numbers in this assay, from the lowest: compound 1; then compounds 3 and 2 (each within the scatter of the next).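

In this assay, for the compounds shown here, this is the first reading of a change at this position, on the aromatic carbon of the five-membered ring next to the ring nitrogen: 4-fluoro-3,5-dimethylphenyl in place of 4-methylphenyl gives a 1.3-fold lower number from compound 2 to compound 3 (0.13 log units; within the scatter). The entering group has 9 heavy atoms against 7 and adds fluorine, yet the read-out stays within the scatter, so this position accepts that larger aryl group with no measurable shift in this assay. No measured information is available to explain why the two compounds read alike.

This single step changes the substituents on the phenyl ring in more than one way, so the compounds shown do not separate any contribution of the fluorine from that of the methyl groups, and a 4-fluorophenyl or 3,5-dimethylphenyl group at this position would be needed to do so. They also leave open whether the same position would accept an aryl group bearing an amine or a carboxylic acid, or a longer alkyl chain in place of the aryl group.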